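The source may report more compounds than this note shows. Statements on the series, on what has been measured and on what is new or still open speak of the compounds shown alone.

Measured compounds:
Compound 1, `Cc1ccc(C(C2c3onc(C)c3N=C(c3ccccc3)CC2c2ccccc2)C2c3onc(C)c3N=C(c3ccccc3)CC2c2ccccc2)cc1`, gives 38.4 ug/mL in a functional assay on HeLa cells (Homo sapiens) for cytotoxicity, read by MTT assay, with a stated time of 48 h; a lower number here means a stronger inhibitor, a higher number a weaker inhibitor.
Compound 2, `Cc1noc2c1N=C(c1ccccc1)CC(c1ccccc1)C2C(c1ccc(Cl)cc1)C1c2onc(C)c2N=C(c2ccccc2)CC1c1ccccc1`, gives 55.9 ug/mL.
Compound 3, `COc1ccc(C(C2c3onc(C)c3N=C(c3ccccc3)CC2c2ccccc2)C2c3onc(C)c3N=C(c3ccccc3)CC2c2ccccc2)cc1`, gives 65.9 ug/mL.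

The three values lie close together. Compound 3 differs from compound 2 by a 1.2-fold higher number from compound 2 to compound 3 (0.07 log units; within the scatter) and from compound 1 by a 1.7-fold higher number from compound 1 to compound 3 (0.23 log units; within the scatter), and compound 1 and compound 2 differ by a 1.5-fold higher number from compound 1 to compound 2 (0.16 log units; within the scatter); none of these gaps exceeds the scatter. Only the group on the outer aromatic ring changes among them, and swapping methyl, chloro and methoxy has left the read-out essentially unchanged.

Compound 4, `Cc1noc2c1N=C(c1ccccc1)CC(c1ccccc1)C2C(c1ccccc1)C1c2onc(C)c2N=C(c2ccccc2)CC1c1ccccc1`, takes this one step further: hydrogen in place of methoxy on an aromatic carbon. Read at the next bond, the change is 4-methoxyphenyl to phenyl. The measured steps that bear on it are the three just named, all small, so a hydrogen at that position is expected to behave like the other groups tried there. The step of a 1.3-fold lower number from compound 3 to compound 4 (0.12 log units; within the scatter) is therefore expected to stay within the scatter, in no particular direction. Compound 4 is estimated to give about 50 ug/mL in this assay, with a likely range from 25 ug/mL to 100 ug/mL.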

Compound 4, half-maximal inhibitory concentration: 68.7 ug/mL
The estimate for compound 4 lay 1.4-fold (0.14 log units) below the measured number, and the stated range covers the measured number.
By their numbers in this assay, from the lowest: compounds 1, 2, 3 and 4 (each within the scatter of the next).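

Hydrogen is the smallest change possible at this position, on an aromatic carbon para to a large group, and it still gives only small steps in this assay (a 1.0-fold higher number from compound 3 to compound 4 (0.02 log units; within the scatter)), (a 1.2-fold higher number from compound 2 to compound 4 (0.09 log units; within the scatter)) and (a 1.8-fold higher number from compound 1 to compound 4 (0.25 log units; within the scatter)). The earlier compounds shown here compared only one substituent with another, whereas compound 4 adds the plain phenyl ring as a reference point and shows that, across these four compounds, methyl, chloro and methoxy give no result beyond the scatter of that unsubstituted ring. No measurement shown here explains why this position makes so little difference.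

Going by these compounds, it remains open whether an amine, a carboxylic acid or a longer chain at this position would also sit within the scatter of compound 4. The compounds also leave open how changes elsewhere on the shared core would affect the read-out.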